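Swapping trifluoromethyl for hydroxy on the anilide ring

This account rests on a few compounds, and the source may have more. Where it says the series, first, only, none or still open, it means among the compounds named here.

compound 1 `O=C(Nc1ccccc1C(F)(F)F)C1CCc2ccccc2N1C(=O)c1ccccc1Cl`: 2730 nM
compound 2 `O=C(Nc1ccccc1C(F)(F)F)C1CCc2ccccc2N1`: 39300 nM

In a functional assay on NUGC-3 cells (Homo sapiens) for cytotoxicity, read by sulforhodamine B assay, with a stated time of 72 h (on this read-out lower numbers stand for stronger inhibition of growth and higher numbers for weaker inhibition of growth), compound 1 gives 2730 nM and stands lowest of the two numbers. Compound 2 gives 39300 nM. For the measured compounds named here, the only measured step, a 14-fold higher number from compound 1 to compound 2 (1.16 log units; beyond the scatter), concerns the nitrogen of the shared core, not the anilide ring. Compound 3 `O=C(Nc1ccccc1O)C1CCc2ccccc2N1C(=O)c1ccccc1Cl` differs from compound 1 by hydroxy in place of trifluoromethyl on an aromatic carbon. Going by the values given here, no measured step bears on this position, so the size and direction of the change are open. Compound 3 is expected to stay near compound 1, with a wide range, as the step of a 1.5-fold higher number from compound 1 to compound 3 (0.17 log units; within the scatter) expresses. Compound 3 is estimated at 4000 nM, between 1000 nM and 20000 nM.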

Compound 3, concentration for 50% growth inhibition: 36800 nM
Estimate against measurement, compound 3: 9.2-fold (0.96 log units) below, outside the stated range (above it).
By their numbers in this assay, from the lowest: compound 1; then compounds 3 and 2 (each within the scatter of the next).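

In this assay the anilide ring proves sensitive to this change: the step of a 13-fold higher number from compound 1 to compound 3 (1.13 log units; beyond the scatter) is large, so hydroxy does not stand in for trifluoromethyl on this aromatic carbon. A change here thus moves the number beyond the scatter, as does the change on the nitrogen of the shared core, a 14-fold higher number from compound 1 to compound 2 (1.16 log units; beyond the scatter). Nothing shown here accounts for the step. As far as these compounds go, what a methoxy group or a chlorine atom on this carbon would give stays open.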